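The source may report more compounds than this note shows. Statements on the series, on what has been measured and on what is new or still open speak of the compounds shown alone.

Compound 3 `Fc1cccc(COc2ccc(Nc3ncnc4cc(C#CCN5CCNCC5)sc34)cc2Cl)c1` is reported in an ADME assay on HepG2 cells (Homo sapiens) for cytotoxicity (on this read-out lower numbers stand for higher toxicity in this test and higher numbers for lower toxicity in this test), only as a limit, > 29 uM. For the measured compounds named here, it is the only one of the measured compounds reported this way: the limit of > 29 uM in this assay, at which 1 of the 3 values shown sits. Compound 4 `Fc1cccc(COc2ccc(Nc3ncnc4cc(C#CC5CCCC5)sc34)cc2Cl)c1` has cyclopentyl in place of (piperazin-1-yl)methyl on a triple-bonded carbon.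

Going by the values given here, no measured step makes this exact change, but three steps exchange groups on a saturated chain carbon bound to a triple-bonded carbon. In this assay, compound 1 `CC(C)(C)CC#Cc1cc2ncnc(Nc3ccc(OCc4cccc(F)c4)c(Cl)c3)c2s1` gives 29.3 uM and compound 2 `CCCN(CC#Cc1cc2ncnc(Nc3ccc(OCc4cccc(F)c4)c(Cl)c3)c2s1)CCC` gives 26.5 uM. The tert-butyl to dipropylamino change gives a 1.1-fold lower number from compound 1 to compound 2 (0.04 log units; within the scatter). The dipropylamino to piperazin-1-yl change gives an at least 1.0-fold higher number from compound 2 to compound 3 (0.03 log units; that floor lies within the scatter). The remaining step is a step that the limit leaves unreadable from compound 1 to compound 3.

None of these steps has a readable size beyond the scatter, so no step beyond the scatter is expected in this assay, and no direction is expected either. The expected step is an at least 1.0-fold lower number from compound 3 to compound 4 (0.03 log units; that floor lies within the scatter). For compound 4 the estimated value is 27 uM, with an expected range from 14 uM to 45 uM.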

Compound 4, half-maximal toxic concentration: > 31 uM
Compound 4 ended at the assay's limit; the forecaster's own chance of this, stated with the estimate: 40%; at least 1.1-fold (0.05 log units) between middle value and limit.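

Compound 4, with cyclopentyl on the triple-bonded carbon, is again reported only as a limit: the limit of > 31 uM in this assay, at which 1 of the 4 values shown sits.

The step between compound 3 and compound 4 cannot be read, as both numbers are limits. The two steps that can be read, an at least 1.1-fold higher number from compound 2 to compound 4 (0.06 log units; that floor lies within the scatter) and an at least 1.0-fold higher number from compound 1 to compound 4 (0.02 log units; that floor lies within the scatter), show that cyclopentyl set directly on the triple-bonded carbon gives no lower number in this assay than the neopentyl or (dipropylamino)methyl groups do.

The actual values of compound 3 and compound 4 stay open, so the compounds shown do not rank piperazin-1-yl against cyclopentyl at this place. Also open, as far as these compounds go, is whether a carboxylic acid or a morpholine ring on the same triple-bonded carbon would give a number that differs beyond the scatter.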